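Chromene ester series: triazole substituent swap, compound 4

This account rests on a few compounds, and the source may have more. Where it says the series, first, only, none or still open, it means among the compounds named here.

Compounds measured in a functional assay on MCF7 cells (Homo sapiens) for inhibition, read by MTT assay, with a stated time of 24 h; a lower number here means a stronger inhibitor, a higher number a weaker inhibitor:
- Compound 1 `CCOC(=O)C1=Cc2ccccc2OC1(OCc1cc(-c2ccc(C)cc2)no1)C(F)(F)F` gives > 150000 nM; this is a limit of the assay, not a number.
- Compound 2 `CCOC(=O)C1=Cc2ccccc2OC1(OCc1cn(CC(=O)Nc2ccc(C)cc2)nn1)C(F)(F)F` gives > 150000 nM; this too is a limit of the assay.
- Compound 3 `Cc1ccc(-c2cc(COC3(C(F)(F)F)Oc4ccccc4C=C3C(=O)O)on2)cc1` gives 30100 nM.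

Compound 2 therefore stands at the limit shared with compound 1 (the limit of > 150000 nM in this assay, at which 2 of the 3 values shown sit), and no number is known for it. Within the data shown here, the only measured step, an at least 4.9-fold lower number from compound 1 to compound 3 (0.69 log units; beyond the scatter), concerns the ester, which compound 4 `CCOC(=O)C1=Cc2ccccc2OC1(OCc1cn(-c2ccc(F)c([N+](=O)[O-])c2)nn1)C(F)(F)F` keeps. The change from compound 2 to compound 4 is 4-fluoro-3-nitrophenyl in place of ((4-methylphenyl)carbamoyl)methyl on an aromatic nitrogen. Among the measured compounds shown here, no measured step bears on this change, so no step beyond the scatter is expected in this assay; compound 4 is expected to sit near the limit as well, with a step that the limit leaves unreadable from compound 2 to compound 4. For compound 4 the estimate is 200000 nM, in the range 50000 nM to 600000 nM.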

Compound 4, half-maximal inhibitory concentration: 16200 nM
The estimate for compound 4 lay 12-fold (1.09 log units) above the measured number; the measured number lies below the stated range.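

With the ester kept, the group on the aromatic nitrogen alone moves a compound off the limit in this assay: 4-fluoro-3-nitrophenyl in place of ((4-methylphenyl)carbamoyl)methyl gives an at least 9.2-fold lower number from compound 2 to compound 4 (0.96 log units; beyond the scatter). Earlier, only the free carboxylic acid of compound 3 had left the limit, so the ester of compound 4 does not by itself hold a compound there. The size of the step is only a bound, as compound 2 sits at a limit of the assay: the limit of > 150000 nM in this assay, at which 2 of the 4 values shown sit.

Which part of 4-fluoro-3-nitrophenyl carries the step stays open. Also open, on these data alone, is whether an amine in place of its nitro group would hold the number of compound 4.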